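Swapping Furan-2-yl for Nitro in a Cytotoxicity Screen

A few compounds are considered here, and "the series" means these few. Any claim that something is new, unique, unknown or untested is made for them only; others in the source may bear on it.

Of the compounds shown here, three have so far been measured in an ADME assay on PC-3 cells (Homo sapiens) for cytotoxicity, read by WST assay, tested at 100 uM; on this read-out lower numbers stand for less inhibition and higher numbers for more inhibition at the one concentration tested (going by the name of the read-out). Compound 1 `O=C(Nc1ccc(Cl)cn1)C1CCCN(C(=O)c2cc(C(F)(F)F)cc(C(F)(F)F)c2)C1` gives 0%, compound 2 `O=C(Nc1ccc(Cl)cc1)C1CCCN(C(=O)c2cccc(-c3ccco3)c2)C1` gives 0%, and compound 3 `O=C(Nc1ccc(Cl)cc1)C1CCCN(C(=O)c2cc(C(F)(F)F)cc(C(F)(F)F)c2)C1` gives 14%. Compound 2 thus stands level with compound 1 at the reported digits, and the two together form the lowest pair of the three numbers, while compound 3 gives 14%, the highest of the three.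

Among the compounds with values here, the only step between measured compounds that differ in one place is a number 14 percentage points higher from compound 1 to compound 3 (beyond the scatter), and it concerns the group on the amide-type nitrogen, not the ring carrying the furan. Compound 4 `O=C(Nc1ccc(Cl)cc1)C1CCCN(C(=O)c2cccc([N+](=O)[O-])c2)C1` differs from compound 2 by nitro in place of furan-2-yl on an aromatic carbon, the change sitting on an aromatic carbon of a six-membered aromatic ring of carbon only, meta to a large group. Within the data shown here, no measured step touches that position, so the data offer nothing that would set the size or direction of this change; the outcome is simply open.

Compound 4 is therefore expected to give 3%, with a range from -8% to 15%. That estimate means an expected step of a number 3 percentage points higher from compound 2 to compound 4 (within the scatter), nothing beyond the usual scatter.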

Compound 4, a percentage reported as inhibition, at one concentration (the size of the read-out at that concentration, not a potency): 0%
The estimate for compound 4 lay 3 percentage points above the measured number; measured number inside the range.
By their numbers in this assay, from the lowest: compounds 1, 2 and 4 (each within the scatter of the next); then compound 3.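

In this assay, within the data shown here, nitro in place of furan-2-yl on an aromatic carbon gave no change at the digits printed from compound 2 to compound 4 (within the scatter), the first measured step at this place, on a six-membered aromatic ring of carbon only, meta to a large group. A five-membered aromatic ring with one hetero atom thus gave way to a group with no ring and fewer heavy atoms, and compound 4 gives 0%, so at the one concentration tested the read-out does not separate the two groups. No measurement offered here accounts for this outcome.

From the compounds shown here alone, whether an amine, a carboxylic acid or a longer chain at this same place would also leave the number where it stands remains open, since both groups seen here sit at the bottom of the read-out. Also open, going by these compounds, is whether 4-chlorophenyl in place of 5-chloropyridin-2-yl on an amide-type nitrogen, which gave a number 14 percentage points higher from compound 1 to compound 3 (beyond the scatter), would give a similar step in compounds carrying nitro or furan-2-yl.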